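The compounds below may be only part of what the source reports. "The series", "measured", "known", "first", "only" and "open" are said of these compounds alone.

Compound 1 `C=C(Br)C(=O)Nc1cccc(-c2cn3nc(-c4ccc(F)cc4)sc3n2)c1` gives 830 nM in a functional assay on CCRF-CEM cells (Homo sapiens) for inhibition, read by cell counting, with a stated time of 3 days; on this read-out higher numbers stand for weaker inhibition and lower numbers for stronger inhibition.
Compound 2 `Nc1cccc(-c2cn3nc(CCc4ccccc4)sc3n2)c1` gives 30000 nM in this assay.
Compound 3 `COc1ccc(Cc2nn3cc(-c4cccc(N)c4)nc3s2)cc1` reports only a limit in this assay, >= 250000 nM.

Among the two numbers shown, compound 1 stands lowest, which on this read-out means the strongest inhibition; compound 2 sits well above it. Compound 3 is known only as a limit (the limit of >= 250000 nM in this assay, at which 1 of the 3 values shown sits), so its true number is not fixed. Going by the values given here, the one measured step, an at least 8.3-fold higher number from compound 2 to compound 3 (0.92 log units; beyond the scatter), lies in a different part of the shared core from the change followed here, and both of those compounds lack the bromoacrylamide group that compound 1 carries.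

Compound 4 `C=C(Br)C(=O)Nc1cccc(-c2cn3nc(-c4ccc(C)cc4)sc3n2)c1` differs from compound 1 by a single exchange: methyl in place of fluoro on an aromatic carbon. Among the compounds with values here, no measured step touches this place, so there is no direct guide to its size. The expectation is therefore a step of about a 1.1-fold higher number from compound 1 to compound 4 (0.04 log units; within the scatter), that is, no movement beyond the scatter. Compound 4 is estimated at 900 nM, within a range of 300 nM to 3000 nM.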

Compound 4, half-maximal inhibitory concentration: 1700 nM
Compound 4: middle estimate off by 1.9-fold (0.28 log units), on the low side; measured number inside the range.
By their numbers in this assay, from the lowest: compound 1; then compound 4; then compound 2. At a limit, above all of these: compound 3.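

Going from 4-fluorophenyl to 4-methylphenyl gives the first measured step at this position in this assay: a 2.0-fold higher number from compound 1 to compound 4 (0.31 log units; beyond the scatter). The position therefore responds even to a small change, since one heavy atom is exchanged for one heavy atom, with no hydrogen-bond donor or acceptor and no net charge on either side, and the number still moves toward weaker inhibition. Nothing shown here explains why this exchange has that effect.

As far as these compounds go, two groups at one position cannot establish a trend, so it remains open how a chloro group, an amine or a carboxylic acid in the same place would change the number. From the compounds shown here alone, it also remains open whether this exchange would give a step of similar size in a compound without the bromoacrylamide group.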